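The compounds below may be only part of what the source reports. "The series", "measured", "known", "first", "only" and "open" are said of these compounds alone.

Compound 1 `N#Cc1cnc(-c2ccccc2)nc1N1C[C@@H]2C[C@H]1CN2c1cccc(F)c1` gives the higher of the two values recorded in a physicochemical assay for lipophilicity, read by HPLC (on this read-out lower numbers stand for lower lipophilicity and higher numbers for higher lipophilicity), at 4.5. Compound 2 `C[C@@H]1C[C@H]1C(=O)N1CCN(c2cnc(C#N)c(-c3cnn(C)c3)n2)C[C@H]1C` stands a long way off: in this assay compound 2 gives 1.6, and since no single change links the two, only their values can be set side by side. Compound 3 `Cn1cc(-c2ncc(C#N)c(N3C[C@@H]4C[C@H]3CN4c3cccc(F)c3)n2)cn1` is still to be measured in this assay. It differs from compound 1 in one place: 1-methyl-1H-pyrazol-4-yl in place of phenyl on an aromatic carbon. A clear drop in this assay is expected, a number 1.30 log units lower from compound 1 to compound 3 (beyond the scatter). Compound 3 is therefore estimated at 3.2, within the range 2.6 to 3.8.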

Compound 3, distribution coefficient: 3.1
Compound 3: the middle estimate sits 0.10 log units above what was measured; the range from low to high includes it.
By their numbers in this assay, from the lowest: compound 2; then compound 3; then compound 1.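

In this assay, going by these compounds alone, 1-methyl-1H-pyrazol-4-yl in place of phenyl on an aromatic carbon gives a number 1.40 log units lower from compound 1 to compound 3 (beyond the scatter), the only single change here whose size can be read. Both groups have the same number of heavy atoms, so this large step comes without any change in that count. Nothing measured here accounts for the step.

Within the data shown here, whether the same swap would give a similar step on another core remains open, as this is the only such pair. As far as these compounds go, how an amine or a carboxylic acid at this position would read also remains open.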